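Cytotoxicity notes on a sulfonamide series: compound 4 outlook

The compounds below may be only part of what the source reports. "The series", "measured", "known", "first", "only" and "open" are said of these compounds alone.

Measured so far in an ADME assay on HEK293 cells (Homo sapiens) for cytotoxicity, read by resazurin assay, with a stated time of 48 h; a lower number here means that less compound is tolerated, a higher number that more compound is tolerated:
Compound 1 `COc1ccc(Cl)cc1S(=O)(=O)Nc1ccc(-c2nc3ccccc3o2)cc1` gives 75000 nM.
Compound 2 `C=Cc1ccc(S(=O)(=O)Nc2ccc(-c3nc4ccccc4o3)cc2)cc1` gives > 100000 nM, which is a limit of the assay and not a number.
Compound 3 `O=S(=O)(Nc1ccc2oc(-c3ccccc3)nc2c1)c1ccc(O)cc1` gives > 100000 nM, likewise a limit and not a number.

Compound 2 therefore stands at the upper edge of what this assay reports; its value is only a limit, as is the value of compound 3, so that compound 2 cannot be placed against either of them. Going by the values given here, the one step that is known, an at least 1.3-fold higher number from compound 1 to compound 2 (0.12 log units; that floor lies within the scatter), is bounded below only, and its floor lies within the scatter. The limit of > 100000 nM in this assay, at which 2 of the 3 values shown sit, is the feature of these numbers that matters most for what follows.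

Compound 4 is `O=S(=O)(Nc1ccc(-c2nc3ccccc3o2)cc1)c1ccc(Cl)cc1`. It differs from compound 2 in one place: chloro in place of vinyl on an aromatic carbon. Among the compounds with values here, the known step from compound 1 to compound 2 does not involve this aromatic carbon, so no measured step bears directly on the change. With compound 2 at a limit and compound 1 not far beneath it, no step beyond the scatter is expected in this assay, in either direction.

Compound 4 is accordingly expected to give about 100000 nM, in the range 50000 nM to 200000 nM, and the expected step of a number no higher from compound 2 to compound 4 (the limit leaves the size open) is estimated to stay within the scatter.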

Compound 4, half-maximal cytotoxic concentration: > 100000 nM
Compound 4 was reported as a limit; the forecaster's own chance of this, stated with the estimate: 60%; the middle value sits exactly at the limit.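

Compound 4 gives > 100000 nM in this assay, which is a limit of the assay and not a number, so the 4-chlorophenyl group on the sulfonyl sulfur reads at the same edge as the 4-vinylphenyl group. Chloro and vinyl on this aromatic carbon, para to a large group, therefore cannot be told apart here, and the steps between limits cannot be read. The one readable step, an at least 1.3-fold higher number from compound 1 to compound 4 (0.12 log units; that floor lies within the scatter), repeats what the step to compound 2 showed, with no change established beyond the scatter, and the main feature of the series remains its upper edge: the limit of > 100000 nM in this assay, at which 3 of the 4 values shown sit.

Going by these compounds, how an amine, a carboxylic acid or a longer chain on this aromatic carbon would read in this assay stays open, as does whether any group at this position brings the number down into the readable range. Also open, on these data alone, is how far compound 2 and compound 4 lie past the limit, and so whether either truly differs from compound 1.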